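Moving Trifluoromethyl on the Aryl Attached to Ring Nitrogen

The source may hold more compounds than are shown below. What is called first, only, known or untested is meant among the compounds shown, and "the series" means these compounds.

Measured so far in a functional assay on MDA-MB-231 cells (Homo sapiens) for antiproliferative activity, read by MTT assay, with a stated time of 48 h; a lower number here means a stronger inhibitor, a higher number a weaker inhibitor:
Compound 1 `C/C(=C\CC/C(C)=C/CC[C@@H]1[C@@]2(C)CCC(=O)C(C)(C)[C@H]2CC[C@@]1(C)O)CC/C=C(\C)C(=O)OCc1cn(-c2ccccc2Cl)nn1` gives > 150000 nM, a limit of the assay rather than a number.
Compound 2 `C/C(=C\CC/C(C)=C/CC[C@@H]1[C@@]2(C)CCC(=O)C(C)(C)[C@H]2CC[C@@]1(C)O)CC/C=C(\C)C(=O)OCc1cn(-c2cccc(O)c2)nn1` gives 139000 nM.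
Compound 3 `C/C(=C\CC/C(C)=C/CC[C@@H]1[C@@]2(C)CCC(=O)C(C)(C)[C@H]2CC[C@@]1(C)O)CC/C=C(\C)C(=O)OCc1cn(-c2ccc(C(F)(F)F)cc2)nn1` gives > 150000 nM, again a limit and not a number.

Compound 3 therefore stands at the limit of > 150000 nM in this assay, at which 2 of the 3 values shown sit, with no measured number of its own. Compound 4 `C/C(=C\CC/C(C)=C/CC[C@@H]1[C@@]2(C)CCC(=O)C(C)(C)[C@H]2CC[C@@]1(C)O)CC/C=C(\C)C(=O)OCc1cn(-c2ccccc2C(F)(F)F)nn1` differs from it in one place: 2-(trifluoromethyl)phenyl in place of 4-(trifluoromethyl)phenyl on an aromatic nitrogen. Two measured steps reach compound 3. The step that the two limits leave unreadable from compound 1 to compound 3 joins two limits and cannot be sized. The step of an at least 1.0-fold higher number from compound 2 to compound 3 (0.03 log units; that floor lies within the scatter) is known only as a floor, and that floor lies within the scatter. Among the compounds with values here, neither step is readable in size, and none of the measured compounds carries a 2-(trifluoromethyl)phenyl group, so the change in compound 4 has no direct precedent. Compound 1, which carries a 2-chlorophenyl group, also sits at that limit. Compound 3 sits there as well. Both anchor the expectation for compound 4 near or beyond the limit. Compound 4 is expected to give 200000 nM, in the range 100000 nM to 500000 nM. The expected step that the limit leaves unreadable from compound 3 to compound 4 is estimated to lie within the scatter, with a good chance that only a limit is returned.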

Compound 4, half-maximal inhibitory concentration: > 150000 nM
Compound 4: no number, only a limit (the forecaster's own chance of this, stated with the estimate: 75%); the middle value does not contradict the limit.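

With the trifluoromethyl group in 2-(trifluoromethyl)phenyl instead of 4-(trifluoromethyl)phenyl, the result in this assay remains a limit, so both placings of this group on the aryl leave the assay without a number: the limit of > 150000 nM in this assay, at which 3 of the 4 values shown sit.

Within the data shown here, the one step with any readable size is an at least 1.0-fold higher number from compound 2 to compound 4 (0.03 log units; that floor lies within the scatter), which gives no sign of a real difference between the 3-hydroxyphenyl and 2-(trifluoromethyl)phenyl groups. The steps to compound 4 from compound 3 and from compound 1 join two limits and cannot be read, so this position change has no measurable size, and neither does the swap of chloro for trifluoromethyl.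

The compounds shown leave open whether any group on this aryl can bring a clear gain over compound 2, which gives 139000 nM, the only measured number among them. An amine or a carboxylic acid on the aryl, in place of the trifluoromethyl, would test whether a readable number can be reached from this position.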